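The source may hold more compounds than are shown below. What is called first, only, known or untested is meant among the compounds shown, and "the series" means these compounds.

In a functional assay on SJ-G2 cells (Homo sapiens) for inhibition, read by MTT assay, with a stated time of 72 h (a higher number here means a weaker inhibitor of growth, a lower number a stronger inhibitor of growth), compound 1 `N#C/C(=C\c1ccc(Cl)cc1)C(=O)c1ccc[nH]1` gives 37000 nM, and compound 2 `N#C/C(=C\c1c(F)c(F)c(F)c(F)c1F)C(=O)c1ccc[nH]1` gives 23000 nM. Compound 3 `COc1ccc(CNC(=O)/C(C#N)=C/c2ccc[nH]2)cc1` reaches only a limit of the assay, > 50000 nM, so that its standing is known only as the limit of > 50000 nM in this assay, at which 1 of the 3 values shown sits. Compound 4 `COc1ccc(CNC(=O)/C(C#N)=C/c2ccc(Br)o2)cc1` has not yet been measured in this assay. It differs from compound 3 in one place: 5-bromofuran-2-yl in place of 1H-pyrrol-2-yl on a double-bonded chain carbon bound to a double-bonded chain carbon. Among the compounds with values here, no measured pair shows this change, so its size is not known from these data. Compound 4 is expected to give about 40000 nM, with a range from 12000 nM to 100000 nM. This amounts to an expected step of an at least 1.2-fold lower number from compound 3 to compound 4 (0.09 log units; that floor lies within the scatter), leaning toward stronger growth inhibition, though a limit again would not surprise.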

Compound 4, concentration for 50% growth inhibition: 13000 nM
The estimate for compound 4 lay 3.1-fold (0.49 log units) above the measured number, and the stated range covers the measured number.
By their numbers in this assay, from the lowest: compounds 4, 2 and 1 (each within the scatter of the next, the first and the last beyond it). At a limit, above all of these: compound 3.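

In this assay, 5-bromofuran-2-yl in place of 1H-pyrrol-2-yl on a double-bonded chain carbon bound to a double-bonded chain carbon gives the first step seen at this place, an at least 3.8-fold lower number from compound 3 to compound 4 (0.58 log units; beyond the scatter). Compound 4 thus gives a real number where compound 3 gives only a limit. The step is therefore a floor and its full size remains unknown: the limit of > 50000 nM in this assay, at which 1 of the 4 values shown sits.

The change swaps nitrogen for oxygen in the ring and also adds bromine, so the compounds shown do not separate these two differences. As far as these compounds go, whether plain furan-2-yl or 5-methylfuran-2-yl would give a similar number stays open.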